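Two Measured Chalcones and an Unmeasured Dichlorophenyl Analogue

A few compounds are considered here, and "the series" means these few. Any claim that something is new, unique, unknown or untested is made for them only; others in the source may bear on it.

compound 1 `COc1ccc(-c2cc(/C=C/C(=O)c3ccc(N)cc3)[nH]n2)cc1`: 91%
compound 2 `COc1cc(-c2cc(/C=C/C(=O)c3ccc(N)cc3)[nH]n2)cc(OC)c1OC`: 90%

In a functional assay on SK-MEL-28 cells (Homo sapiens) for cytotoxicity, read by sulforhodamine B assay, with a stated time of 48 h, tested at 1 uM (on this read-out higher numbers stand for a weaker effect at the one concentration tested and lower numbers for a stronger effect), compound 1 gives 91%. In this assay compound 2 gives 90%, the lower of the two numbers, though it lies within the scatter of compound 1, so the two show no difference of note. Compound 3 `COc1cc(-c2cc(/C=C/C(=O)c3ccc(Cl)c(Cl)c3)[nH]n2)cc(OC)c1OC` has not been measured. It differs from compound 2 in this way: 3,4-dichlorophenyl in place of 4-aminophenyl on a carbonyl carbon. Within the data shown here, no measured pair shows a step of this kind, so the expected step of a number 5 percentage points lower from compound 2 to compound 3 (within the scatter) is small and not beyond the scatter. Compound 3 is expected to give 85%, in a range from 65% to 100%.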

Compound 3, a percentage reported as activity, at one concentration (the size of the read-out at that concentration, not a potency): 114%
Compound 3: middle estimate off by 29 percentage points, on the low side; measured number above the stated range.
By their numbers in this assay, from the lowest: compounds 2 and 1 (each within the scatter of the next); then compound 3.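

In this assay, the group on the carbonyl carbon proves able to move the read-out: 3,4-dichlorophenyl in place of 4-aminophenyl gives a number 24 percentage points higher from compound 2 to compound 3 (beyond the scatter), a weaker effect at the one concentration tested. Compound 1 and compound 2 both carry 4-aminophenyl there, so they could not show this. No measurement given here accounts for the direction of this step.

The two rings differ in more than one substituent, so the change cannot be assigned to the loss of the amine or to the arrival of the chlorines. On these data alone, how a single chlorine, a hydroxyl or a carboxylic acid on that ring would read remains open.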